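This account rests on a few compounds, and the source may have more. Where it says the series, first, only, none or still open, it means among the compounds named here.

Compounds measured so far:
compound 1 `ClCc1ccc(Cn2cnc3c(Cl)ncnc32)cc1` gives 1950 nM
compound 2 `Nc1nc(Cl)c2ncn(Cc3ccc(CCl)cc3)c2n1` gives 4900 nM

Both numbers come from a functional assay on HCT-15 cells (Homo sapiens) for cytotoxicity, read by sulforhodamine B assay, with a stated time of 48 h; a lower number here means a stronger inhibitor of growth, a higher number a weaker inhibitor of growth. Compound 2 stands at the highest of the two numbers; its nearest neighbour is compound 1, and the step of a 2.5-fold higher number from compound 1 to compound 2 (0.40 log units; beyond the scatter) is a modest one that lies beyond the scatter. That step consists of nothing more than an amino group being added to the shared core.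

Compound 3 `ClCc1ccc(Cn2cnc3c(Cl)nc(Cl)nc32)cc1` has not been measured. It differs from compound 2 in one place: chloro in place of amino on an aromatic carbon. Among the compounds with values here, the only measured step that bears on this change is a 2.5-fold higher number from compound 1 to compound 2 (0.40 log units; beyond the scatter), which shows that adding the amino group raised the number; taking the amino group away again may therefore be expected to bring the number back down toward that of compound 1. Within the data shown here, no measured step shows what a chloro group does at this position, so the expectation carries a wide range.

For compound 3 in this assay the estimate is 2000 nM, with a range from 800 nM to 5000 nM, which corresponds to an expected step of a 2.5-fold lower number from compound 2 to compound 3 (0.39 log units; beyond the scatter).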

Compound 3, concentration for 50% growth inhibition: 1860 nM
The estimate for compound 3 lay 1.1-fold (0.03 log units) above the measured number; the range from low to high includes it.
By their numbers in this assay, from the lowest: compounds 3 and 1 (each within the scatter of the next); then compound 2.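

In this assay, the aromatic carbon between two ring nitrogen atoms now has three occupants on the shared core, and chloro there proves no different from hydrogen within the scatter (a 1.0-fold lower number from compound 1 to compound 3 (0.02 log units; within the scatter)). Putting chloro in place of amino on that same carbon gives the other new step (a 2.6-fold lower number from compound 2 to compound 3 (0.42 log units; beyond the scatter)), so among these three compounds the amino group of compound 2 alone stands apart, while compound 1 and compound 3 cannot be told apart. Nothing measured here explains why amino stands apart from hydrogen and chloro at this position.

Whether a different group on this carbon, such as methoxy, methylamino or a longer chain, would read like amino or like chloro remains open, since only these three occupants are shown. Also open, on these data alone, is whether the same picture would hold if the chloro group meta to this carbon gave way to an amine, as all three compounds carry that chloro group unchanged.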